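Taking one methyl off compound 2

This account rests on a few compounds, and the source may have more. Where it says the series, first, only, none or still open, it means among the compounds named here.

Compound 1 `COc1cc2nc(N3CCCC3)nc(NS(=O)(=O)c3ccc(C)cc3)c2cc1OC` gives 8.61 ug/mL
Compound 2 `COc1cc2nc(Cl)nc(NS(=O)(=O)c3ccc(C)cc3C)c2cc1OC` gives 65.1 ug/mL
Compound 3 `COc1cc2nc(Cl)nc(NS(=O)(=O)Cc3cccc(I)c3)c2cc1OC` gives 66.5 ug/mL
Compound 4 `COc1cc2nc(Cl)nc(NS(=O)(=O)c3ccc(C)cc3)c2cc1OC` has no value yet

In a functional assay on U-937 cells (Homo sapiens) for cytotoxicity, read by MTT assay, with a stated time of 24 h (on this read-out lower numbers stand for stronger inhibition and higher numbers for weaker inhibition), compound 2 sits with compound 3 at the high, weaker end, and compound 1 gives a clearly lower number. Compound 4 differs from compound 2 in one place, (hydrogen in place of methyl on an aromatic carbon), hydrogen in place of methyl on an aromatic carbon, so 2,4-dimethylphenyl becomes 4-methylphenyl. For the measured compounds named here, the one measured step at this sulfonyl sulfur is a 1.0-fold higher number from compound 2 to compound 3 (0.01 log units; within the scatter), and that wider swap of 3-iodobenzyl for 2,4-dimethylphenyl stayed within the scatter. Compound 1 shares the 4-methylphenyl but differs elsewhere on the core, so it says little here. No step beyond the scatter is expected in this assay, and the expected step is a 1.1-fold lower number from compound 2 to compound 4 (0.04 log units; within the scatter) for this change. Compound 4 is estimated at 60 ug/mL, within a range of 28 ug/mL to 125 ug/mL for now.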

Compound 4, half-maximal inhibitory concentration: 39.9 ug/mL
Compound 4: middle estimate off by 1.5-fold (0.18 log units), on the high side; the measured number falls inside the stated range.
By their numbers in this assay, from the lowest: compound 1; then compounds 4, 2 and 3 (each within the scatter of the next).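

In this assay, taking off this methyl gives a 1.6-fold lower number from compound 2 to compound 4 (0.21 log units; within the scatter) as the ring position changes to hydrogen, so the two groups cannot be told apart here. Setting 4-methylphenyl in place of 3-iodobenzyl on the sulfonyl sulfur gives a 1.7-fold lower number from compound 3 to compound 4 (0.22 log units; within the scatter) and also stays within the scatter. Only the change on the core clears the scatter, with chloro in place of pyrrolidin-1-yl giving a 4.6-fold higher number from compound 1 to compound 4 (0.67 log units; beyond the scatter) as the sole such step among these three. Going by these compounds, whether an amine or a carboxylic acid at this ring position would move the number stays open. Nothing measured here explains these steps.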